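A few compounds are considered here, and "the series" means these few. Any claim that something is new, unique, unknown or untested is made for them only; others in the source may bear on it.

Measured compounds:
Compound 1 `O=C(Nc1ccc(Br)cc1)c1cn(-c2ccccc2)nc1-c1ccccc1` gives 4470 nM in a functional assay on HCT-116 cells (Homo sapiens) for cytotoxicity, read by MTT assay, with a stated time of 48 h; a higher number here means a weaker inhibitor, a lower number a stronger inhibitor.
Compound 2 `COc1ccc(NC(=O)c2cn(-c3ccccc3)nc2-c2ccccc2)cc1` gives 1350 nM.
Compound 3 `CCOc1ccc(NC(=O)c2cn(-c3ccccc3)nc2-c2ccccc2)cc1` gives 620 nM.

Among these three, compound 1 has the highest number and is therefore the weakest inhibitor of the set; the nearest to it is compound 2, a 3.3-fold lower number from compound 1 to compound 2 (0.52 log units; beyond the scatter), and the furthest is compound 3, a 7.2-fold lower number from compound 1 to compound 3 (0.86 log units; beyond the scatter).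

Compound 4 `COc1ccc(-c2nn(-c3ccccc3)cc2C(=O)Nc2ccc(Br)cc2)cc1` differs from compound 1 in one place: methoxy in place of hydrogen on an aromatic carbon. The measured steps all concern a different part of the shared core: they replace the bromo of compound 1 with methoxy, a 3.3-fold lower number from compound 1 to compound 2 (0.52 log units; beyond the scatter), or with ethoxy, a 7.2-fold lower number from compound 1 to compound 3 (0.86 log units; beyond the scatter), or lengthen methoxy to ethoxy, a 2.2-fold lower number from compound 2 to compound 3 (0.34 log units; beyond the scatter). Among the compounds with values here, they show that this assay responds clearly to changes at that bromo site, but none of them touches the phenyl that becomes 4-methoxyphenyl in compound 4, and no measured compound carries any group on that phenyl. Within the data shown here, there is thus no step of the same kind to lean on.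

With nothing to support a shift in either direction, the expectation is that compound 4 lands close to compound 1, with no step beyond the scatter, a 1.3-fold lower number from compound 1 to compound 4 (0.11 log units; within the scatter). The estimate for compound 4 in this assay is 3500 nM, within a range from 1100 nM to 11000 nM.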

Compound 4, half-maximal inhibitory concentration: 5870 nM
Compound 4: the middle estimate sits 1.7-fold (0.22 log units) below what was measured; measured number inside the range.
By their numbers in this assay, from the lowest: compound 3; then compound 2; then compounds 1 and 4 (each within the scatter of the next).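

In this assay, within the data shown here, this is the first look at the phenyl that becomes 4-methoxyphenyl, and the new methoxy on its aromatic carbon gives a 1.3-fold higher number from compound 1 to compound 4 (0.12 log units; within the scatter), so compounds 1 and 4 cannot be told apart in this assay. The earlier compounds showed only that the bromo site responds, and the same methoxy group placed there gives a 3.3-fold lower number from compound 1 to compound 2 (0.52 log units; beyond the scatter), beyond the scatter; among these compounds, then, the outcome of adding a methoxy depends on where it sits, and this phenyl accepts the group with no measurable step. No measurement at hand accounts for this difference between the two sites.

On these data alone, a single group at a single place on this phenyl says little about the position as a whole, so it remains open whether a hydroxy group, an amine, a carboxylic acid or a longer chain such as butoxy would also leave the number within the scatter. As far as these compounds go, it is also open whether 4-methoxyphenyl would remain just as silent on the ethoxy-bearing compound 3, which has the lowest number here.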